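Swapping the para substituent of the benzyl ether in compound 1

A few compounds are considered here, and "the series" means these few. Any claim that something is new, unique, unknown or untested is made for them only; others in the source may bear on it.

Compound 1 `COc1cccc(OC)c1OCCNCCOc1ccccc1OCc1ccc(Cl)cc1` is a diaryl-ether-linked amine with a benzyl ether on one ring. In a functional assay on PC-3 cells (Homo sapiens) for cytotoxicity, read by sulforhodamine B assay (on this read-out higher numbers stand for weaker inhibition of growth and lower numbers for stronger inhibition of growth), compound 1 gives 14500 nM, the lower of the two numbers recorded. Compound 2 `COc1cccc(OC)c1OCCNCCOc1ccccc1OCc1ccc(C)cc1`, where methyl replaces chloro on an aromatic carbon, gives 27500 nM in this assay; the step from compound 1 to compound 2 is a 1.9-fold higher number from compound 1 to compound 2 (0.28 log units; within the scatter), so the two cannot be told apart. Compound 3 `COc1cccc(OC)c1OCCNCCOc1ccccc1OCc1ccc(OC(C)C)cc1` differs from compound 1 by isopropoxy in place of chloro on an aromatic carbon. Going by the values given here, the only step that bears on this exchange is the methyl-for-chloro step within the scatter, and nothing recorded here speaks for a larger effect of isopropoxy at the same place. The step from compound 1 to compound 3 is therefore expected to be small, a 1.4-fold higher number from compound 1 to compound 3 (0.14 log units; within the scatter). Compound 3 is estimated at 20000 nM, with a likely range from 7000 nM to 60000 nM.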

Compound 3, concentration for total growth inhibition: 17800 nM
Compound 3: the middle estimate sits 1.1-fold (0.05 log units) above what was measured; measured number inside the range.
By their numbers in this assay, from the lowest: compounds 1, 3 and 2 (each within the scatter of the next).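

In this assay, isopropoxy brings 4 heavy atoms and 1 hydrogen-bond acceptor to the place where chloro has 1 heavy atom and no acceptor, yet the exchange gives a 1.2-fold higher number from compound 1 to compound 3 (0.09 log units; within the scatter) and stays within the scatter. Measured against the methyl group, the same place gives a 1.5-fold lower number from compound 2 to compound 3 (0.19 log units; within the scatter) in this comparison, so chloro, methyl and isopropoxy on this aromatic carbon, para to a large group, cannot be told apart in this read-out. Nothing available here offers an explanation for this result.

From the compounds shown here alone, whether this holds for a charged or strongly different group at this place, such as an amine or a carboxylic acid, remains open. Also open, going by these compounds, is whether a longer chain in place of isopropoxy would move the number beyond the scatter.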